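A Heteroaryl Exchange on Compound 2, Before Measurement

A few compounds are considered here, and "the series" means these few. Any claim that something is new, unique, unknown or untested is made for them only; others in the source may bear on it.

Compound 2 `Nc1n[nH]c2cc(-c3cn([C@@H]4CN[C@H](C(=O)Nc5ccc(Cl)cc5Cl)C4)nn3)ccc12` gives, in a functional assay on K562/Adr cells (Homo sapiens) for inhibition, read by MTT assay, with a stated time of 48 h, tested at 30 uM (on this read-out lower numbers stand for less inhibition and higher numbers for more inhibition at the one concentration tested (going by the name of the read-out)), 29.4%. Among the compounds with values here, the only other number belongs to compound 1 `CC(C)(C)OC(=O)N1C[C@@H](n2cc(-c3ccc4c(N)n[nH]c4c3)nn2)C[C@H]1C(=O)Nc1ccc(Cl)cc1Cl`, which in this assay gives 25.6%; the step of a number 3.8 percentage points higher from compound 1 to compound 2 (within the scatter) lies within the scatter, so the two compounds are not told apart. Within the data shown here, that step, hydrogen in place of tert-butoxycarbonyl on an amine nitrogen in a ring, is the single measured step in this set, and it alters a different part of the molecule from the change considered here.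

Compound 3 `Nc1nc2ccc(-c3cn([C@@H]4CN[C@H](C(=O)Nc5ccc(Cl)cc5Cl)C4)nn3)nc2s1` differs from compound 2 by a group of 10 heavy atoms (6 carbon, 3 nitrogen, 1 sulfur; one five-membered aromatic ring with 2 hetero atoms, one six-membered aromatic ring with 1 hetero atom) in place of a group of 10 heavy atoms (7 carbon, 3 nitrogen; one five-membered aromatic ring with 2 hetero atoms, one six-membered aromatic ring of carbon only), on an aromatic carbon. Among the measured compounds shown here, no measured step bears on this exchange, and the one step that was measured stayed within the scatter. The expected step of a number 0.4 percentage points lower from compound 2 to compound 3 (within the scatter) is therefore none beyond the scatter, with a wide margin for the unknown. Compound 3 is estimated to give 29%, between 10% and 52%.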

Compound 3, a percentage reported as inhibition, at one concentration (the size of the read-out at that concentration, not a potency): 42.2%
Beside the measured number, compound 3's estimate is 13.2 percentage points below it; low and high end bracket the measured number.
By their numbers in this assay, from the lowest: compounds 1 and 2 (each within the scatter of the next); then compound 3.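

In this assay, within the data shown here, the aromatic carbon of the five-membered aromatic ring with 3 nitrogen is the first place in this set where a change moves the number beyond the scatter: a number 12.8 percentage points higher from compound 2 to compound 3 (beyond the scatter). The two groups have the same number of heavy atoms, so they are not separated by that count; they differ in the sulfur atom, the hetero atom in the six-membered ring, and their hydrogen-bond donor and acceptor counts. Nothing available shows which of these differences goes with the step, and no cause can be assigned.

Going by these compounds, it remains open whether the sulfur atom or the ring nitrogen alone would give a similar step. Also open, on these data alone, is how a hydroxyl or a methylamino group in place of the amine on the entering group would read.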